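This account rests on a few compounds, and the source may have more. Where it says the series, first, only, none or still open, it means among the compounds named here.

Working notes on the aryl group at the amine nitrogen of the six-membered non-aromatic ring with two nitrogens, all other parts of the core held constant. Compound 1 `CSc1ccccc1N1CCN(CCCCn2ncc(=O)n(C)c2=O)CC1` carries a 2-(methylsulfanyl)phenyl there; in an assay for displacement of a labelled ligand from Adrenergic receptor alpha-1 (Homo sapiens) (on this read-out higher numbers stand for weaker inhibition and lower numbers for stronger inhibition), compound 1 gives 1.8 nM. Compound 2 `Cn1c(=O)cnn(CCCCN2CCN(c3cccc(O)c3)CC2)c1=O` carries a 3-hydroxyphenyl instead. In this assay compound 2 reaches only a limit of the assay, > 10000 nM, not a number. Compound 3 `Cn1c(=O)cnn(CCCCN2CCN(c3ncccc3F)CC2)c1=O` carries a 3-fluoropyridin-2-yl. In this assay compound 3 likewise yields only a limit, > 10000 nM. Compound 3 therefore sits at the weak end of everything shown, together with compound 2 (the limit of > 10000 nM in this assay, at which 2 of the 3 values shown sit), and the step that the two limits leave unreadable from compound 2 to compound 3 cannot be read. Both departures from compound 1 were large losses: an at least 5500-fold higher number from compound 1 to compound 2 (3.74 log units; beyond the scatter) and an at least 5500-fold higher number from compound 1 to compound 3 (3.74 log units; beyond the scatter).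

Compound 4 `Cn1c(=O)cnn(CCCCN2CCN(c3ccccc3S)CC2)c1=O` carries the change (2-sulfanylphenyl in place of 3-fluoropyridin-2-yl on an amine nitrogen in a ring), a return to a sulfur-bearing phenyl of the kind found in compound 1. Since an at least 5500-fold higher number from compound 1 to compound 3 (3.74 log units; beyond the scatter) was a large loss, its reversal here is expected to be a large gain, an at least 1000-fold lower number from compound 3 to compound 4 (3.00 log units; beyond the scatter). Compound 4 is accordingly estimated near 10 nM, expected to fall between 2 nM and 150 nM.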

Compound 4, inhibition constant: > 10000 nM
Compound 4 gave a limit, no number (the forecaster's own chance of this, stated with the estimate: 5%); middle value at least 1000-fold (3.00 log units) away from the limit.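

Compound 4 shows that a sulfur on the phenyl is not enough by itself: in this assay compound 4 reaches only a limit of the assay, > 10000 nM, not a number. Hydrogen in place of methyl on the sulfur is the only change separating the pair, and it gives an at least 5500-fold higher number from compound 1 to compound 4 (3.74 log units; beyond the scatter), so in this pair the methyl on sulfur is required for a measurable value. The steps among compound 2, compound 3 and compound 4 cannot be read, as all three share one limit: the limit of > 10000 nM in this assay, at which 3 of the 4 values shown sit.

Going by these compounds, whether the sulfur itself is needed remains open, and a 2-methoxyphenyl group would address that. Also open, on these data alone, is how much size the group on sulfur tolerates, as with 2-(ethylsulfanyl)phenyl, and whether 3-(methylsulfanyl)phenyl keeps any of the binding of compound 1.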